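A few compounds are considered here, and "the series" means these few. Any claim that something is new, unique, unknown or untested is made for them only; others in the source may bear on it.

Three compounds share one core and differ only in the aromatic ring attached to one of the two carbonyl groups. Compound 1 `CC(C)(C)N(NC(=O)c1ccccc1F)C(=O)c1ccccc1Cl` gives 51.3 nM in an assay on cells for agonist activity at ecdysone receptor (Bombyx mori), read by a luciferase reporter, with a stated time of 24 h; a lower number here means that less compound is needed, a higher number that more compound is needed for the effect. Compound 2 `Cc1ccccc1C(=O)NN(C(=O)c1ccccc1Cl)C(C)(C)C` gives 72.4 nM, and the two lie close together: a 1.4-fold higher number from compound 1 to compound 2 (0.15 log units; within the scatter). Compound 3 `Cc1cccc(C(=O)NN(C(=O)c2ccccc2Cl)C(C)(C)C)c1` gives 603 nM, the highest number of the three, with a clear gap to both neighbours: a 12-fold higher number from compound 1 to compound 3 (1.07 log units; beyond the scatter) and an 8.3-fold higher number from compound 2 to compound 3 (0.92 log units; beyond the scatter).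

Compound 4 `COc1cccc(C(=O)NN(C(=O)c2ccccc2Cl)C(C)(C)C)c1` is not yet measured. It keeps the core of compound 3 and changes one group: methoxy in place of methyl on an aromatic carbon. Among the measured compounds shown here, none of the measured steps swaps a methyl for a methoxy, so nothing here shows directly how this exchange acts; the measured steps only show that compound 3 already stands well apart from compounds 1 and 2 on this ring. For the measured compounds named here, with no step bearing on the change itself, the expected step from compound 3 to compound 4 is a 1.0-fold lower number from compound 3 to compound 4 (0.00 log units; within the scatter), not beyond the scatter. Compound 4 is therefore estimated at 600 nM, with a range from 200 nM to 1800 nM.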

Compound 4, half-maximal effective concentration: 52.5 nM
For compound 4 the middle estimate is 11-fold (1.06 log units) above the measured one; the measured number lies below the stated range.
By their numbers in this assay, from the lowest: compounds 1, 4 and 2 (each within the scatter of the next); then compound 3.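

At this place on the ring, meta to a large group, the choice of group matters greatly in this assay (an 11-fold lower number from compound 3 to compound 4 (1.06 log units; beyond the scatter)). Among the compounds shown here, the high number of compound 3 therefore does not come with the position alone, as the earlier compounds might have suggested: it depends on which group sits there. The 3-methoxyphenyl ring also matches the two rings that gave low numbers, with both steps within the scatter (a 1.4-fold lower number from compound 2 to compound 4 (0.14 log units; within the scatter); a 1.0-fold higher number from compound 1 to compound 4 (0.01 log units; within the scatter)), and no measurement here accounts for the size of the methyl-to-methoxy step.

As far as these compounds go, with only methyl and methoxy compared at this place, it remains open how a hydroxy group, an ethoxy group or an amine would read there. From the compounds shown here alone, whether methoxy would give a similar number on other carbons of this ring also stays open.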